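Bromo for tert-butyl on the aryl ether of compound 2

A few compounds are considered here, and "the series" means these few. Any claim that something is new, unique, unknown or untested is made for them only; others in the source may bear on it.

Measured so far:
compound 1 `NC1=NC2(CCSCC2)N(OCCCOc2ccc(Cl)c(Cl)c2)C(N)=N1`, 88.4%
compound 2 `CC(C)(C)c1ccc(OCCCON2C(N)=NC(N)=NC23CCSCC3)cc1`, 85.3%
compound 3 `COc1ccc(OCCCON2C(N)=NC(N)=NC23CCOCC3)cc1`, > 90%

In an assay on isolated protein for inhibition of Dihydrofolate reductase (Homo sapiens), read by spectrophotometry, using NADPH, with stated times of 5 s and 6 min, tested at 5 uM (a higher number here means a stronger effect of the compound at the concentration tested, a lower number a weaker effect), compound 2 gives 85.3%, the lower of the two numbers reported; compound 1 gives 88.4%, and the two lie within the scatter of each other. Compound 3 is reported only as a limit of the assay, > 90%, as noted in the limit of > 90% in this assay, at which 1 of the 3 values shown sits.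

Compound 4 `NC1=NC2(CCSCC2)N(OCCCOc2ccc(Br)cc2)C(N)=N1` has not been measured. It differs from compound 2 in one place: bromo in place of tert-butyl on an aromatic carbon. Among the compounds with values here, no step between two measured compounds isolates such a change, and compound 1, which also carries halogens on the same aromatic ring, sits within the scatter of compound 2. The step from compound 2 to compound 4 in this assay is therefore expected to be small, a number 1.7 percentage points higher from compound 2 to compound 4 (within the scatter), none beyond the scatter in either direction. Compound 4 is estimated at 87%, with a range from 76% to 94%.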

Compound 4, a percentage reported as inhibition, at one concentration (the size of the read-out at that concentration, not a potency): > 90%
Compound 4: only a limit was reported; the forecaster's own chance of this, stated with the estimate: 25%; at least 3 percentage points between middle value and limit.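

In this assay compound 4 is reported only as a limit, > 90%. Bromo in place of tert-butyl on this aromatic carbon gives a number at least 4.7 percentage points higher from compound 2 to compound 4 (that floor lies within the scatter), and 4-bromophenyl in place of 3,4-dichlorophenyl gives a number at least 1.6 percentage points higher from compound 1 to compound 4 (that floor lies within the scatter). So at this position, 1 heavy atom can replace the 4 heavy atoms of tert-butyl while the inhibition stays high, but neither floor shows a gain beyond the scatter, and the read-out gives no exact number for compound 4: the limit of > 90% in this assay, at which 2 of the 4 values shown sit.

Going by these compounds, how far compound 4 lies past its limit remains open, as does the true size of both steps. So does whether an amine, a carboxylic acid or a longer chain on this aromatic carbon would keep the inhibition at this level.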